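A few compounds are considered here, and "the series" means these few. Any claim that something is new, unique, unknown or untested is made for them only; others in the source may bear on it.

Working notes on the selenium-bearing series. The shared core appears in compound 1 `CCCCC[Se]c1nc([Se]CCCCC)c2cccnc2n1`, compound 2 `Nc1nc([SeH])nc2ncccc12`, compound 3 `[SeH]c1nc([SeH])c2cccnc2n1` and the still unmeasured compound 4 `CCCCC[Se]c1nc(N)c2cccnc2n1`. Growth inhibition is followed in a functional assay on HT-29 cells (Homo sapiens) for cytotoxicity, read by MTT assay, with a stated time of 72 h; on this read-out higher numbers stand for weaker inhibition of growth and lower numbers for stronger inhibition of growth. In this assay compound 1 returns only a limit, > 100000 nM. In this assay compound 2 gives 89600 nM. For compound 3 this assay records "not determined" (no result reported). Among the compounds with values here, compound 2 thus stands as the only compound with a single number in this assay; one further entry is a limit, the other carries no result. That limit is the limit of > 100000 nM in this assay, at which 1 of the 3 values shown sits. Within the data shown here, no step between two measured compounds is available, so the move from compound 2 to compound 4 rests on the structural change alone: pentyl in place of hydrogen on a selenium. Compound 2 gives a number, 89600 nM. Compound 1, with pentyl on both selenium atoms, returns only a limit in this assay. Compound 4 is therefore expected to shift by a 1.7-fold higher number from compound 2 to compound 4 (0.22 log units; within the scatter), towards weaker inhibition if anything, with a fair chance that only a limit is returned. The estimate for compound 4 is 150000 nM, with a range from 50000 nM to 400000 nM.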

Compound 4, concentration for total growth inhibition: 20000 nM
For compound 4 the middle estimate is 7.5-fold (0.88 log units) above the measured one; measured number outside the range, below it.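

Pentyl in place of hydrogen on a selenium gives a 4.5-fold lower number from compound 2 to compound 4 (0.65 log units; beyond the scatter) in this assay, so the first readable step at this position runs towards stronger inhibition of growth. One nitrogen atom in place of the pentyl-bearing selenium group on an aromatic carbon gives an at least 5.0-fold lower number from compound 1 to compound 4 (0.69 log units; beyond the scatter), so one pentyl on selenium goes with a measurable number when that nitrogen is present. Compound 1, with pentyl on both selenium atoms, remains a limit and not a number: the limit of > 100000 nM in this assay, at which 1 of the 4 values shown sits.

On these data alone, whether a shorter chain such as ethyl, a longer chain such as octyl, or a pentyl ending in a carboxylic acid on the selenium would follow the same direction stays open. With a single step at this position, its size cannot be carried over to any other group.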